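This account rests on a few compounds, and the source may have more. Where it says the series, first, only, none or still open, it means among the compounds named here.

Three close relatives of one amide-linked pair of aromatic rings have been tested in a functional assay on MDA-MB-468 cells (Homo sapiens) for cytotoxicity, read by MTT assay, with a stated time of 48 h; on this read-out lower numbers stand for stronger inhibition and higher numbers for weaker inhibition. Compound 1 `Cc1ccc(-c2csc(NC(=O)COc3ccccc3)n2)cc1` carries a methyl group on its outer ring, and in this assay compound 1 gives 54900 nM. Compound 2 `O=C(COc1ccccc1)Nc1nc(-c2ccc(Br)cc2)cs1` differs from compound 1 by a bromo in place of methyl on an aromatic carbon. In this assay compound 2 gives 37200 nM, so the step of a 1.5-fold lower number from compound 1 to compound 2 (0.17 log units; within the scatter) is small and does not stand out from the noise of repeated measurement. Compound 3 `Cc1ccc(OCC(=O)Nc2nc(-c3ccc(C)cc3)cs2)cc1` differs from compound 1 at the other end of the molecule, with a methyl in place of hydrogen on an aromatic carbon. In this assay compound 3 gives 37200 nM, and the step of a 1.5-fold lower number from compound 1 to compound 3 (0.17 log units; within the scatter) is likewise within the scatter. So far, then, none of the three numbers can be told apart with confidence.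

Compound 4 `Cc1ccc(OCC(=O)Nc2nc(-c3ccc(Br)cc3)cs2)cc1` has not yet been measured. It differs from compound 3 by a bromo in place of methyl on an aromatic carbon, the same change that separated compound 1 from compound 2. Because that earlier step a 1.5-fold lower number from compound 1 to compound 2 (0.17 log units; within the scatter) was within the scatter, compound 4 is expected to sit close to compound 3, with an estimated step of a 1.2-fold lower number from compound 3 to compound 4 (0.09 log units; within the scatter). Compound 4 is therefore estimated at 30000 nM, expected to fall between 15000 nM and 60000 nM.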

Compound 4, half-maximal inhibitory concentration: 44900 nM
Beside the measured number, compound 4's estimate is 1.5-fold (0.18 log units) below it; measured number inside the range.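

Within this assay, bromo in place of methyl on the outer ring, the change from 4-methylphenyl to 4-bromophenyl, gives a 1.2-fold higher number from compound 3 to compound 4 (0.08 log units; within the scatter), and this step agrees with its earlier counterpart on the other core: the same change on two cores in this assay, a 1.5-fold lower number (0.17 log units; within the scatter) from compound 1 to compound 2 and a 1.2-fold higher number (0.08 log units; within the scatter) from compound 3 to compound 4, 1.8-fold (0.25 log units) apart, within the scatter of two such steps. The second change, methyl in place of hydrogen on an aromatic carbon at the other end of the molecule, gives a 1.2-fold higher number from compound 2 to compound 4 (0.08 log units; within the scatter), and it also agrees with its earlier counterpart: the same change on two cores in this assay, a 1.5-fold lower number (0.17 log units; within the scatter) from compound 1 to compound 3 and a 1.2-fold higher number (0.08 log units; within the scatter) from compound 2 to compound 4, 1.8-fold (0.25 log units) apart, within the scatter of two such steps. This shows that neither change behaves measurably differently on the two cores, but all four steps lie within the scatter, so it does not show that either change has a real effect of its own, that the effect has a consistent direction, or that it would carry to any further core.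

The compounds shown cover only methyl or bromo on the outer ring and only hydrogen or methyl on the other ring, so it remains open whether any change at these places can produce a step that stands clear of the scatter. From the compounds shown here alone, an amine, a carboxylic acid or a longer chain at either place could test this, and whether the pairs of steps would still agree for such groups also stays open.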